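Five-membered heteroaryl swap at the saturated ring carbon

The source may hold more compounds than are shown below. What is called first, only, known or untested is meant among the compounds shown, and "the series" means these compounds.

Measured compounds:
Compound 1, `Cc1ccc([C@@H]2CN(C)[C@]3(C(=O)Nc4ccccc43)[C@]23Cc2ccccc2C3=O)cc1`, gives 17.1% in a functional assay on the whole organism (strain Wister albino) for inhibition, with Rattus norvegicus as the target, read by paw edema, with stated times of 1 h and 4 h, at a dose of 50 mg/kg by the intraperitoneal route; on this read-out higher numbers stand for more inhibition at the one dose given (going by the name of the read-out) and lower numbers for less inhibition.
Compound 2, `CN1C[C@@H](c2ccc(F)cc2)[C@@]2(Cc3ccccc3C2=O)[C@@]12C(=O)Nc1ccccc12`, gives 21.8% in this assay.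
Compound 3, `CN1C[C@@H](c2cccs2)[C@@]2(Cc3ccccc3C2=O)[C@@]12C(=O)Nc1ccccc12`, gives 20% in this assay.

Compound 3 stands second highest of the three numbers in this assay. Its nearest neighbour is compound 2, with a number 1.8 percentage points lower from compound 2 to compound 3 (within the scatter); its furthest is compound 1, with a number 2.9 percentage points higher from compound 1 to compound 3 (within the scatter). Both of these steps are within the scatter, as is a number 4.7 percentage points higher from compound 1 to compound 2 (within the scatter), so the three measured compounds are not separated by this read-out, and no ordering among them can be claimed.

Compound 4, `CN1C[C@@H](c2ccco2)[C@@]2(Cc3ccccc3C2=O)[C@@]12C(=O)Nc1ccccc12`, differs from compound 3 in one place: furan-2-yl in place of thiophen-2-yl on a saturated ring carbon. For the measured compounds named here, the steps that bear on this change are the two that exchange the group on the same saturated ring carbon, a number 2.9 percentage points higher from compound 1 to compound 3 (within the scatter) and a number 1.8 percentage points lower from compound 2 to compound 3 (within the scatter), and both were within the scatter. Three different groups at this position thus gave numbers that cannot be told apart in this assay. A fourth group of the same ring size and heteroatom count is therefore expected to give no step beyond the scatter, no change at the digits printed from compound 3 to compound 4 (within the scatter).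

Compound 4 is estimated at 20% in this assay, with an expected range from 12% to 28%.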

Compound 4, a percentage reported as inhibition, in the whole organism at one dose (the size of the read-out at that dose, not a potency): 33.5%
Estimate against measurement, compound 4: 13.5 percentage points below; measured number outside the range, above it.
By their numbers in this assay, from the lowest: compounds 1, 3 and 2 (each within the scatter of the next); then compound 4.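

At this saturated ring carbon, the group can separate compounds in this assay: furan-2-yl in place of thiophen-2-yl, two five-membered aromatic rings that differ in their hetero atom, oxygen for sulfur, gives a number 13.5 percentage points higher from compound 3 to compound 4 (beyond the scatter). Furan-2-yl also stands clear of the two substituted phenyl groups, with a number 11.7 percentage points higher from compound 2 to compound 4 (beyond the scatter) and a number 16.4 percentage points higher from compound 1 to compound 4 (beyond the scatter), whereas thiophen-2-yl, 4-fluorophenyl and 4-methylphenyl could not be told apart. The position is therefore not indifferent to the group it carries, and among these four compounds only furan-2-yl stands apart, although all three steps are modest and the comparison rests on one compound with this group at a single dose.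

Nothing available accounts for the difference between furan-2-yl and thiophen-2-yl. Still open, from the compounds shown here alone, is whether the higher number extends to other groups at this carbon, such as furan-3-yl, pyrrol-2-yl or an unsubstituted phenyl, or is confined to furan-2-yl.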